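A few compounds are considered here, and "the series" means these few. Any claim that something is new, unique, unknown or untested is made for them only; others in the source may bear on it.

Series notes. Compound 1 `O=C(Nc1cccc(-n2cc(-c3ccncc3)c(-c3ccc(Cl)c(O)c3)n2)c1)Nc1ccc(Cl)c(Cl)c1` is the parent of this pair. In a functional assay on DU-145 cells (Homo sapiens) for inhibition, read by sulforhodamine B assay, with a stated time of 48 h (on this read-out higher numbers stand for lower toxicity in this test and lower numbers for higher toxicity in this test), compound 1 gives > 32500 nM, which is a limit of the assay and not a number. Compound 2 `COc1cc(-c2nn(-c3cccc(NC(=O)Nc4ccc(Cl)c(C(F)(F)F)c4)c3)cc2-c2ccncc2)ccc1Cl` in this assay gives > 32500 nM, again a limit. Compound 3 `COc1cc(-c2nn(-c3cccc(NC(=O)c4ccccc4)c3)cc2-c2ccncc2)ccc1Cl` in this assay gives > 100000 nM, also a limit. Of the three values shown, one sits at the limit of > 100000 nM in this assay, at which 1 of the 3 values shown sits, and two at the limit of > 32500 nM in this assay, at which 2 of the 3 values shown sit. Compound 1 therefore stands at a limit together with compound 2, and no ranking among the three is possible. Among the measured compounds shown here, the one single-point step among the measured compounds, a step that the two limits leave unreadable from compound 2 to compound 3, is unreadable, both ends being limits.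

Compound 4 `O=C(Nc1cccc(-n2cc(-c3ccncc3)c(-c3ccc(Cl)c(O)c3)n2)c1)Nc1cccc(C(F)(F)F)c1` is the next analogue of compound 1. The change is 3-(trifluoromethyl)phenyl in place of 3,4-dichlorophenyl on an amide-type nitrogen. No measured step matches this change: the only step shown, from compound 2 to compound 3, alters the group on the carbonyl carbon rather than the amide-type nitrogen, and it is unreadable in any case. Hence no step beyond the scatter can be expected in this assay in either direction, and the most likely outcome is that compound 4, like compound 1, is reported only as a limit. Compound 4 is estimated in this assay at 40000 nM, with a range from 15000 nM to 100000 nM. The step this estimate means, a step that the limit leaves unreadable from compound 1 to compound 4, is expected to be essentially none.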

Compound 4, concentration lethal to 50% of the cells: > 32500 nM
Compound 4 gave a limit, no number; the forecaster's own chance of this, stated with the estimate: 80%; the middle value is on the limit's open side.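

In this assay compound 4 gives > 32500 nM, a limit of the assay and not a number. Compound 1 is also reported only as a limit, and the step from compound 1 to compound 4 cannot be read. Still open is whether 3-(trifluoromethyl)phenyl and 3,4-dichlorophenyl on an amide-type nitrogen differ at all in this test, since none of the compounds shown has a value that is a number.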